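Swapping Chloro for Bromo at a Limit of the Assay

The compounds below may be only part of what the source reports. "The series", "measured", "known", "first", "only" and "open" are said of these compounds alone.

In a functional assay on CCRF-CEM cells (Homo sapiens) for inhibition (on this read-out higher numbers stand for weaker inhibition and lower numbers for stronger inhibition), compound 1 (`COc1cc(NC(=O)Nc2cccc(C)c2)ccc1-c1cnco1`) gives 2300 nM, a measured number that differs from compound 2 in more than one place. Compound 2 (`CC(C)(C)NC(=O)C(=O)Nc1ccc(-c2cnco2)c(Cl)c1`) is recorded at > 10000 nM, which is a limit of the assay and not a number. As far as these compounds go, it is one of the two values shown, as the limit of > 10000 nM in this assay, at which 1 of the 2 values shown sits, makes clear, so its true position remains open.

Compound 3 (`CC(C)(C)NC(=O)C(=O)Nc1ccc(-c2cnco2)c(Br)c1`) differs from compound 2 at a single place, with bromo in place of chloro on an aromatic carbon, ortho to a 1,3-oxazol-5-yl group and meta to a large group: bromo in place of chloro on an aromatic carbon. Going by the values given here, no measured pair in this small set shows what such a swap does in this assay. The expectation therefore rests on compound 2 at > 10000 nM and on the small size of the change. The expected step, a step that the limit leaves unreadable from compound 2 to compound 3, is estimated to stay within the usual scatter, with no direction favoured, and another reading at the limit is the likeliest outcome. Compound 3 is expected at about 11000 nM, with an estimated range of 5000 nM to 30000 nM.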

Compound 3, half-maximal inhibitory concentration: 5500 nM
The estimate for compound 3 lay 2.0-fold (0.30 log units) above the measured number; the range from low to high includes it.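

In this assay, bromo in place of chloro on an aromatic carbon, ortho to a 1,3-oxazol-5-yl group and meta to a large group, gives an at least 1.8-fold lower number from compound 2 to compound 3 (0.25 log units; that floor lies within the scatter). Going by these compounds alone, this is the first reading of the change at this position, and compound 3 gives a measured number where the chloro compound gave none, so the bromo compound can be placed on the scale of this read-out. Since that floor lies within the scatter, the swap is not shown to change inhibition beyond what repeated measurements could produce, and compound 2 stays a limit of the assay and not a number: the limit of > 10000 nM in this assay, at which 1 of the 3 values shown sits.

As far as these compounds go, how far compound 3 truly lies from compound 2 stays open, since only a floor for the step can be read, and a single pair gives no trend for halogens at this position. Also open, from the compounds shown here alone, is what an iodo group, a nitrile or an amine on the same aromatic carbon would give in this assay, and whether bromo in place of chloro would have a similar effect on a different core.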